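The source may hold more compounds than are shown below. What is called first, only, known or untested is meant among the compounds shown, and "the series" means these compounds.

In a functional assay on MRC5 cells (Homo sapiens) (a higher number here means that more compound is tolerated, a lower number that less compound is tolerated), the three measured compounds sit close together. Compound 1, `COc1ccc(CN2C(=O)c3ccccc3N(Cc3ccc(OC)cc3)S2(=O)=O)cc1`, gives 57000 nM. Compound 2, `COc1ccc(CN2c3ccccc3C(=O)N(Cc3ccccc3)S2(=O)=O)cc1`, gives 61000 nM, which is the highest of the two numbers shown, yet the step of a 1.1-fold higher number from compound 1 to compound 2 (0.03 log units; within the scatter) stays within the scatter. Compound 3, `O=C1c2ccccc2N(Cc2ccccc2-c2ccccc2)S(=O)(=O)N1Cc1ccccc1-c1ccccc1`, reaches only a limit of this assay, > 47000 nM, so that no number is available for it; the one limit shown in this set is the limit of > 47000 nM in this assay, at which 1 of the 3 values shown sits.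

Compound 4, `O=C1c2ccccc2N(CCCc2ccccc2)S(=O)(=O)N1Cc1ccccc1`, differs from compound 2 in a single place: phenethyl in place of 4-methoxyphenyl on a saturated chain carbon bound to a sulfonamide nitrogen in a ring. Within the data shown here, the only measured step that bears on this change is the removal of a methoxy from compound 1 to compound 2, which moved the number by a margin inside the scatter, and no measured step addresses the lengthening of the chain itself. The present change also removes a methoxy, on the other side of the shared core, so a step of similar size is expected, with no clear direction beyond the scatter: a 1.1-fold lower number from compound 2 to compound 4 (0.04 log units; within the scatter) is the expected outcome. Compound 4 is therefore estimated at 55000 nM, within a range from 25000 nM to 120000 nM.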

Compound 4, half-maximal cytotoxic concentration: > 57000 nM
Compound 4: a limit, no number (the forecaster's own chance of this, stated with the estimate: 30%); at least 1.0-fold (0.01 log units) between middle value and limit.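

In this assay, among these compounds, compound 4 gives only a limit, > 57000 nM, and no number, so no step from compound 2 to compound 4 can be read. The compounds shown leave open whether 3-phenylpropyl in place of 4-methoxybenzyl changes the number in this assay at all.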